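The source may report more compounds than this note shows. Statements on the series, on what has been measured and on what is new or still open speak of the compounds shown alone.

Three compounds have been measured in an ADME assay on the whole organism with Oryza sativa as the target, tested at 1 uM; on this read-out higher numbers stand for a weaker effect at the one concentration tested and lower numbers for a stronger effect:

Compound 1, `Cc1ccccc1NC(=O)N[C@@H](C)c1ccccc1`: 99%
Compound 2, `CC(C)c1ccccc1NC(=O)N[C@@H](C)c1ccccc1`: 96%
Compound 3, `C[C@H](NC(=O)Nc1ccccc1F)c1ccccc1`: 92%

Compound 3 returns the lowest of the three numbers, but the gaps to its neighbours, a number 4 percentage points lower from compound 2 to compound 3 (within the scatter) and a number 7 percentage points lower from compound 1 to compound 3 (within the scatter), both lie within the scatter, so the three compounds are not separated on this read-out.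

Compound 4, `C[C@H](NC(=O)Nc1ccccc1Cl)c1ccccc1`, differs from compound 3 by a single change: chloro in place of fluoro on an aromatic carbon. Within the data shown here, none of the measured steps involves chloro, so the bearing of the earlier data is indirect. What they do show is that every swap at this aromatic carbon so far, a number 3 percentage points lower from compound 1 to compound 2 (within the scatter), a number 7 percentage points lower from compound 1 to compound 3 (within the scatter) and a number 4 percentage points lower from compound 2 to compound 3 (within the scatter), stayed within the scatter. On that basis the step expected for compound 4 is a number 1 percentage points higher from compound 3 to compound 4 (within the scatter), that is, no step beyond the scatter in this assay. The estimate for compound 4 is therefore 93%, with a range from 84% to 100%.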

Compound 4, a percentage reported as activity, at one concentration (the size of the read-out at that concentration, not a potency): 104%
Estimate against measurement, compound 4: 11 percentage points below; measured number above the stated range.
By their numbers in this assay, from the lowest: compounds 3, 2, 1 and 4 (each within the scatter of the next, the first and the last beyond it).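

In this assay, among these compounds, a number 12 percentage points higher from compound 3 to compound 4 (beyond the scatter) is the first step at this aromatic carbon, ortho to a large group, to be printed as beyond the scatter, so the position is not wholly indifferent to what sits on it. The separation holds only for this pair of halogens: a number 8 percentage points higher from compound 2 to compound 4 (within the scatter) and a number 5 percentage points higher from compound 1 to compound 4 (within the scatter) are both within the scatter, so compound 4 is not told apart from the methyl and isopropyl compounds. No evidence at hand bears on this step.

On these data alone, it remains open whether another group on this carbon, such as bromo, methoxy, an amine or a carboxylic acid, would fall with the fluoro compound, with the chloro compound or outside both. As far as these compounds go, it is also open whether the chloro for fluoro change gives a step of similar size on a core other than this one.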